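Swapping an ethoxy for chloro on an arylpiperazine

The source may hold more compounds than are shown below. What is called first, only, known or untested is meant among the compounds shown, and "the series" means these compounds.

Two close relatives of one shared core have been measured. Compound 1 `COC(=O)C1=C(C)NC(=O)N(C(=O)NCCCN2CCN(c3ccccc3OC)CC2)C1c1ccc(F)c(F)c1` carries a methoxy group on its terminal aromatic ring, and in an assay on liver for binding affinity to Alpha-1A adrenergic receptor (Homo sapiens), using microsomes (a higher number here means a weaker inhibitor, a lower number a stronger inhibitor), compound 1 gives 0.1 nM. Compound 2 `CCOc1ccccc1N1CCN(CCCNC(=O)N2C(=O)NC(C)=C(C(=O)OC)C2c2ccc(F)c(F)c2)CC1` lengthens that group to an ethoxy, and in this assay compound 2 gives 0.1 nM. Among the compounds with values here, the single step between them, no change at the digits printed from compound 1 to compound 2 (within the scatter), shows that adding one carbon to the alkoxy chain made no difference that rises above the scatter, so compound 2 stands level with compound 1 at the strongest end of what has been measured.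

Compound 3 `COC(=O)C1=C(C)NC(=O)N(C(=O)NCCCN2CCN(c3ccccc3Cl)CC2)C1c1ccc(F)c(F)c1` changes the same position in a different way: chloro in place of ethoxy on an aromatic carbon. Within the data shown here, no measured step in this set tests the loss of the alkoxy oxygen, so the only guidance is that this position tolerated a small lengthening without any shift. A modest weakening is therefore expected rather than a large one, giving an estimated step of a 4.0-fold higher number from compound 2 to compound 3 (0.60 log units; beyond the scatter). In this assay compound 3 is expected to give about 0.4 nM, with a likely range from 0.1 nM to 2 nM.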

Compound 3, inhibition constant: 0.2 nM
Estimate against measurement, compound 3: 2.0-fold (0.30 log units) above, within the range that was stated.
By their numbers in this assay, from the lowest: compounds 1, 2 and 3 (each within the scatter of the next).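

Until now, this position had only been tested by lengthening the alkoxy chain; compound 3 shows that the whole ethoxy group, oxygen included, can give way to a single chlorine atom in this assay without a shift that rises above the scatter. The exchange gives a 2.0-fold higher number from compound 2 to compound 3 (0.30 log units; within the scatter) and, measured against the methoxy group, a 2.0-fold higher number from compound 1 to compound 3 (0.30 log units; within the scatter) on the same aromatic carbon, so among these three compounds an alkoxy oxygen at this place is not needed for a value at this level. No accompanying measurement explains why the methoxy, ethoxy and chloro compounds read so similarly.

Going by these compounds, whether this tolerance reaches other kinds of group remains open: an amine, a carboxylic acid or a longer chain such as butoxy could behave differently, and a plain hydrogen would show whether this place needs any group at all. Within the data shown here, since no step among the three compounds lies beyond the scatter, they do not show which changes at this position would matter, or whether the same exchange would read alike on a different core.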